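Adding a Third Methoxy Group to Compound 3

The source may hold more compounds than are shown below. What is called first, only, known or untested is meant among the compounds shown, and "the series" means these compounds.

Compound 3 `COc1ccc(-c2cc(C(=O)Nc3nc4cc(C)c(C)cc4s3)nc3cc(-c4ccccc4)nn23)cc1OC` gives 6910 nM in a functional assay on DU-145 cells (Homo sapiens) for cytotoxicity, read by MTT assay, with a stated time of 48 h (a higher number here means a weaker inhibitor, a lower number a stronger inhibitor), the lowest of the three numbers measured. Among the compounds with values here, compound 2 `COc1cc(-c2cc(C(=O)Nc3nc4ccc(F)cc4s3)nc3cc(-c4ccccc4)nn23)cc(OC)c1OC` gives 25700 nM, and compound 1 `COc1cc(-c2cc(C(=O)Nc3nc4ccc(Cl)cc4s3)nc3cc(-c4ccccc4)nn23)cc(OC)c1OC` gives 38900 nM; the only single-point step among them, a 1.5-fold lower number from compound 1 to compound 2 (0.18 log units; within the scatter), concerns a halogen exchange. Compound 4 `COc1cc(-c2cc(C(=O)Nc3nc4cc(C)c(C)cc4s3)nc3cc(-c4ccccc4)nn23)cc(OC)c1OC` differs from compound 3 by methoxy in place of hydrogen on an aromatic carbon. Within the data shown here, no measured step bears on this change: compounds 1 and 2 carry the 3,4,5-trimethoxyphenyl group but also a different substitution on the other ring, so they do not isolate it. The expectation is therefore a 1.2-fold higher number from compound 3 to compound 4 (0.06 log units; within the scatter), no step beyond the scatter, with a wide range. Compound 4 is expected to give 8000 nM, between 2500 nM and 25000 nM.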

Compound 4, half-maximal inhibitory concentration: 3710 nM
Compound 4: the middle estimate sits 2.2-fold (0.33 log units) above what was measured, and the stated range covers the measured number.
By their numbers in this assay, from the lowest: compounds 4 and 3 (each within the scatter of the next); then compounds 2 and 1 (each within the scatter of the next).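

Replacing hydrogen with methoxy, which turns 3,4-dimethoxyphenyl into 3,4,5-trimethoxyphenyl, gives a 1.9-fold lower number from compound 3 to compound 4 (0.27 log units; within the scatter) in this assay, so this position accepts the extra group without a measurable difference. With the 3,4,5-trimethoxyphenyl group now held constant, the benzothiazole groups can be compared directly: 5,6-dimethyl in place of 6-fluoro gives a 6.9-fold lower number from compound 2 to compound 4 (0.84 log units; beyond the scatter), and 5,6-dimethyl in place of 6-chloro gives a 10-fold lower number from compound 1 to compound 4 (1.02 log units; beyond the scatter). No available measurement explains these steps. Still open, from the compounds shown here alone, is what an amine or a hydroxyl group at this position would do, and whether the methoxy step holds with the 6-fluoro or 6-chloro benzothiazole.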